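From pyridin-4-yl to pyridin-3-yl on compound 3

The compounds below may be only part of what the source reports. "The series", "measured", "known", "first", "only" and "open" are said of these compounds alone.

In a functional assay on HepG2 cells (Homo sapiens) for antiproliferative activity, read by fluorescence and resazurin assay, with a stated time of 48 h (on this read-out higher numbers stand for weaker inhibition and lower numbers for stronger inhibition), compound 1 (`O=C(N/N=C/c1cccnc1)c1cc2ccccc2oc1=O`) gives 15900 nM, compound 2 (`O=C(N/N=C/c1ccncc1)c1cc2cc(Br)ccc2oc1=O`) gives 4890 nM and compound 3 (`O=C(N/N=C/c1ccncc1)c1cc2cc([N+](=O)[O-])ccc2oc1=O`) gives 15800 nM. Compound 3 lies within the scatter of compound 1 and apart from compound 2.

Compound 4 (`O=C(N/N=C/c1cccnc1)c1cc2cc([N+](=O)[O-])ccc2oc1=O`) is next, with pyridin-3-yl in place of pyridin-4-yl on a carbon with a double bond to nitrogen.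

Among the measured compounds shown here, the only measured single change, nitro in place of bromo, gives a 3.2-fold higher number from compound 2 to compound 3 (0.51 log units; beyond the scatter). It does not touch the pyridine group, so it shows only the size of a modest step in this series. For the measured compounds named here, no measured pair isolates the change from pyridin-4-yl to pyridin-3-yl. Compound 1, which carries pyridin-3-yl without the nitro group, gives 15900 nM, which offers no sign of a shift in either direction. No step beyond the scatter is therefore expected in this assay, and the expected change is a 1.1-fold lower number from compound 3 to compound 4 (0.02 log units; within the scatter). For compound 4 the estimate is 15000 nM, with an expected range of 6500 nM to 35000 nM.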

Compound 4, half-maximal inhibitory concentration: 17000 nM
Estimate against measurement, compound 4: 1.1-fold (0.05 log units) below; low and high end bracket the measured number.
By their numbers in this assay, from the lowest: compound 2; then compounds 3, 1 and 4 (each within the scatter of the next).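

Moving the pyridine attachment on the nitro compounds gives a 1.1-fold higher number from compound 3 to compound 4 (0.03 log units; within the scatter) in this assay, the first direct reading at this place, on a carbon with a double bond to nitrogen: pyridin-4-yl and pyridin-3-yl are not separated here. Nitro in place of hydrogen on an aromatic carbon, read with pyridin-3-yl held fixed, gives a 1.1-fold higher number from compound 1 to compound 4 (0.03 log units; within the scatter), so these two are not separated either, whereas the only step beyond the scatter remains the bromo-to-nitro one with pyridin-4-yl. Nothing available explains why either swap leaves the read-out within the scatter.

Open, as far as these compounds go, is whether bromo would stand apart from nitro and hydrogen with pyridin-3-yl as it does from nitro with pyridin-4-yl. Also open, from the compounds shown here alone, is how an amine or a carboxylic acid on that aromatic carbon, or a phenyl ring in place of the pyridine, would read.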